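Removing a Methoxy From a Compound That Shows No Effect

The source may report more compounds than this note shows. Statements on the series, on what has been measured and on what is new or still open speak of the compounds shown alone.

Compound 2 `COc1cccc(/C=C/C(=O)c2c(OC)cc(OC)cc2OC)c1` was tested in a functional assay on HaCaT cells (Homo sapiens), read by fluorescence and BrdU incorporation, with a stated time of 48 h, tested at 25 uM (a lower number here means a stronger effect, a higher number a weaker effect of the compound at the concentration tested), where compound 2 gives 0%. Compound 1 `COc1cc(OC)c(C(=O)/C=C/c2ccccc2SC)c(OC)c1` gives 0% in this assay, and the step of no change at the digits printed from compound 1 to compound 2 (within the scatter) falls within the scatter. Compound 3 `COc1cc(OC)c(C(=O)/C=C/c2ccccc2)c(OC)c1` differs from compound 2 by hydrogen in place of methoxy on an aromatic carbon. For the measured compounds named here, no measured step touches this particular change; the single measured step concerns a different group and shows nothing at all. With both measured compounds at the same level, the step expected for compound 3 is no change at the digits printed from compound 2 to compound 3 (within the scatter), none beyond the scatter. Compound 3 is therefore estimated at 0%, within -5% to 15%.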

Compound 3, a percentage reported as activity, at one concentration (the size of the read-out at that concentration, not a potency): 0.1%
Compound 3: the middle estimate sits 0.1 percentage points below what was measured; the range from low to high includes it.
By their numbers in this assay, from the lowest: compounds 1, 2 and 3 (each within the scatter of the next).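

In this assay, hydrogen in place of methoxy gives a number 0.1 percentage points higher from compound 2 to compound 3 (within the scatter) and hydrogen in place of methylsulfanyl gives a number 0.1 percentage points higher from compound 1 to compound 3 (within the scatter). The unsubstituted phenyl therefore cannot be told apart from either substituted ring, so neither methoxy nor methylsulfanyl stands out from plain hydrogen on this ring. No measurement here offers an explanation for these readings.

As far as these compounds go, it remains open whether any group on this ring can shift the reading, such as an amine or a carboxylic acid. What the shared core contributes also cannot be told from these compounds.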